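Trifluoromethoxy in place of trifluoromethyl: working notes

The source may report more compounds than this note shows. Statements on the series, on what has been measured and on what is new or still open speak of the compounds shown alone.

Values so far in a functional assay on KB cells (Homo sapiens) for inhibition, read by sulforhodamine B assay (a lower number here means a stronger inhibitor of growth, a higher number a weaker inhibitor of growth), are these
compound 1 `FC(F)(F)Oc1ccc(-c2ccc(-c3ccc(-c4nc5ccccc5[nH]4)cc3)cc2)cc1` gives 39100 nM
compound 2 `Cc1ccc2[nH]c(-c3ccc(-c4ccc(-c5ccccc5)cc4)cc3)nc2c1` gives 32100 nM
compound 3 `Cc1ccc2[nH]c(-c3ccc(-c4ccc(-c5ccc(C(F)(F)F)cc5)cc4)cc3)nc2c1` gives 41200 nM

Compound 3 at 41200 nM lies within the scatter of both other compounds, so none of the three stands apart in this assay on these numbers. Compound 4 `Cc1ccc2[nH]c(-c3ccc(-c4ccc(-c5ccc(OC(F)(F)F)cc5)cc4)cc3)nc2c1` has trifluoromethoxy in place of trifluoromethyl on an aromatic carbon and is otherwise identical to compound 3. Among the measured compounds shown here, no measured step makes this exact exchange. For the measured compounds named here, the one measured step that bears on this place is a 1.3-fold higher number from compound 2 to compound 3 (0.11 log units; within the scatter) and it put trifluoromethyl in place of hydrogen on an aromatic carbon. Compound 1 also carries trifluoromethoxy, and its 39100 nM value lies within the scatter of the value of compound 3. On this evidence, no change beyond the scatter is expected, and the expected step is a 1.0-fold lower number from compound 3 to compound 4 (0.01 log units; within the scatter) with no direction favoured. In this assay compound 4 is estimated at 40000 nM with 22000 nM to 70000 nM as the expected range.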

Compound 4, concentration for 50% growth inhibition: 41200 nM
For compound 4 the middle estimate is 1.0-fold (0.01 log units) below the measured one, within the range that was stated.
By their numbers in this assay, from the lowest: compounds 2, 1, 3 and 4 (each within the scatter of the next).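

The direct exchange at this position, on an aromatic carbon para to a large group, gives no change at the digits printed from compound 3 to compound 4 (within the scatter) in this assay and so does not tell trifluoromethoxy from trifluoromethyl. Against hydrogen at the same place, trifluoromethoxy gives a 1.3-fold higher number from compound 2 to compound 4 (0.11 log units; within the scatter) and thus stays as close to the unsubstituted compound as trifluoromethyl does. Methyl in place of hydrogen on an aromatic carbon of the shared core gives a 1.1-fold higher number from compound 1 to compound 4 (0.02 log units; within the scatter) and so, with compound 4 at 41200 nM in this assay, none of the single changes among these compounds moves the number beyond the scatter.

As far as these compounds go, whether a group of another kind at this position, such as an amine or a carboxylic acid, would do so stays open. Nothing at hand speaks to a cause for these numbers.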